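Fluoro to methyl on the chain carbon of compound 3

The source may report more compounds than this note shows. Statements on the series, on what has been measured and on what is new or still open speak of the compounds shown alone.

Compound 1 `Cc1cccc(C)c1-c1cccc(COc2ccc(CC(F)C(=O)O)cn2)c1` gives 8.6 nM in a functional assay on CHO cells for agonist activity at Free fatty acid receptor 1 (Homo sapiens), read by calcium flux; a higher number here means that more compound is needed for the effect, a lower number that less compound is needed.
Compound 2 `COC(Cc1ccc(OCc2cccc(-c3c(C)cccc3C)c2)nc1)C(=O)O` gives 120 nM in this assay.
Compound 3 `Cc1cccc(C)c1-c1cccc(COc2ccc(C(F)CC(=O)O)cn2)c1` gives 18 nM in this assay.

Compound 3 stands second of the three numbers, with compound 1 nearest at a 2.1-fold higher number from compound 1 to compound 3 (0.32 log units; beyond the scatter) and compound 2 furthest at a 6.7-fold lower number from compound 2 to compound 3 (0.82 log units; beyond the scatter). Compound 4 `Cc1cccc(C)c1-c1cccc(COc2ccc(C(C)CC(=O)O)cn2)c1` differs from compound 3 by methyl in place of fluoro on a saturated chain carbon bound to an aromatic carbon and a saturated chain carbon. Within the data shown here, no measured step replaces fluoro with methyl; the only step that exchanges the chain fluoro is a 14-fold higher number from compound 1 to compound 2 (1.14 log units; beyond the scatter), a large shift, but at a different chain carbon and with methoxy entering. A smaller step is therefore expected in this assay, probably toward a higher number; the estimated step is a 1.7-fold higher number from compound 3 to compound 4 (0.22 log units; within the scatter). Compound 4 is expected to give about 30 nM, in a range from 9 nM to 100 nM.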

Compound 4, half-maximal effective concentration: 10 nM
Estimate against measurement, compound 4: 3.0-fold (0.48 log units) above; the measured number falls inside the stated range.
By their numbers in this assay, from the lowest: compounds 1, 4 and 3 (each within the scatter of the next, the first and the last beyond it); then compound 2.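

On this saturated chain carbon bound to an aromatic carbon and a saturated chain carbon, methyl serves as well as fluoro in this assay (a 1.8-fold lower number from compound 3 to compound 4 (0.26 log units; within the scatter)), so the fluoro is not needed there. The 1-(carboxymethyl)ethyl group also stays level with 2-carboxy-2-fluoroethyl (a 1.2-fold higher number from compound 1 to compound 4 (0.07 log units; within the scatter)), whereas 2-carboxy-2-methoxyethyl remains well apart (a 12-fold lower number from compound 2 to compound 4 (1.08 log units; beyond the scatter)). Nothing shown gives a reason for these numbers. As far as these compounds go, whether a hydroxyl or an ethyl group on this carbon would fit equally well stays open.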